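The compounds below may be only part of what the source reports. "The series", "measured", "known", "first", "only" and "open" are said of these compounds alone.

Compound 3 `O=C(c1ccncc1)N1N=C(c2cc3ccccc3o2)CC1c1ccccc1[N+](=O)[O-]` carries a 2-nitrophenyl group on a saturated ring carbon of the shared core. In an ADME assay on Vero cells (Chlorocebus sabaeus) for cytotoxicity, read by MTT assay, with a stated time of 72 h (on this read-out lower numbers stand for stronger inhibition and higher numbers for weaker inhibition), compound 3 gives only a limit, > 245000 nM. Compound 1 `O=C(c1ccncc1)N1N=C(c2cc3ccccc3o2)CC1c1ccc(Cl)cc1` likewise reaches only a limit in this assay, > 220000 nM. Compound 2 `O=C(c1ccncc1)N1N=C(c2cc3ccccc3o2)CC1c1ccccc1Cl` also stops at a limit, > 210000 nM. The steps a step that the two limits leave unreadable from compound 1 to compound 2, a step that the two limits leave unreadable from compound 1 to compound 3 and a step that the two limits leave unreadable from compound 2 to compound 3 thus remain unreadable, as the limit of > 210000 nM in this assay, at which 1 of the 3 values shown sits, the limit of > 220000 nM in this assay, at which 1 of the 3 values shown sits, and the limit of > 245000 nM in this assay, at which 1 of the 3 values shown sits, make plain. Compound 4 `COc1ccc(C2CC(c3cc4ccccc4o3)=NN2C(=O)c2ccncc2)cc1` differs from compound 3 by 4-methoxyphenyl in place of 2-nitrophenyl on a saturated ring carbon. With no readable step on this core, the expected step in this assay is a step that the limit leaves unreadable from compound 3 to compound 4, none beyond the scatter. Compound 4 is therefore estimated at 250000 nM, within 100000 nM to 600000 nM, most likely again as a limit.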

Compound 4, half-maximal inhibitory concentration: > 200000 nM
Compound 4: no number, only a limit; the forecaster's own chance of this, stated with the estimate: 85%; the middle value is on the limit's open side.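

In this assay, among the compounds shown here, compound 4 also gives only a limit, > 200000 nM, so no step linking it to compound 1, compound 2 or compound 3 can be read. The compounds shown leave open whether the group on the saturated ring carbon changes this read-out at all.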